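Cytotoxicity notes on the series, compound 2 to compound 4

A few compounds are considered here, and "the series" means these few. Any claim that something is new, unique, unknown or untested is made for them only; others in the source may bear on it.

Measured compounds and values:
compound 1, `COc1cc(C(=O)/C=C/c2ccc3c(c2)B(O)OC3)cc(OC)c1OC`: > 10 ug/mL
compound 2, `O=C(/C=C/c1ccc2c(c1)B(O)OC2)c1ccco1`: > 10 ug/mL
compound 3, `COc1ccc(C(=O)/C=C/c2ccc3c(c2)B(O)OC3)c(OC)c1`: 7.87 ug/mL

In an ADME assay on L929 cells (Mus musculus) for cytotoxicity, read by resazurin assay, with a stated time of 72 h (on this read-out higher numbers stand for weaker inhibition and lower numbers for stronger inhibition), compound 1 gives > 10 ug/mL, which is a limit of the assay and not a number. Compound 2 gives > 10 ug/mL in this assay, again a limit rather than a number. For the measured compounds named here, compound 3 gives 7.87 ug/mL in this assay and is the only compound with a number. Compound 2 therefore sits at the limit of > 10 ug/mL in this assay, at which 2 of the 3 values shown sit, so its standing relative to the others cannot be placed more closely than that. Going by the values given here, no pair of measured compounds differs in only one place, so no measured step is available in this assay.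

Compound 4, `O=C(/C=C/c1ccc2c(c1)B(O)OC2)c1cccc(F)c1`, has not yet been measured in this assay. It differs from compound 2 by 3-fluorophenyl in place of furan-2-yl on a carbonyl carbon. Among the compounds with values here, with compound 2 known only as a limit and no measured step of this kind, the step that the limit leaves unreadable from compound 2 to compound 4 is expected to be small, none beyond the scatter, and the value is expected to stay near the limit. For compound 4 the estimate in this assay is 12 ug/mL, with a range from 5 ug/mL to 30 ug/mL, and a fair chance that only a limit is reported.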

Compound 4, half-maximal inhibitory concentration: > 10 ug/mL
Compound 4 ended at the assay's limit; the forecaster's own chance of this, stated with the estimate: 55%; the middle value does not contradict the limit.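

Compound 2 and compound 4 both stand only as limits in this assay, so no step can be read for 3-fluorophenyl in place of furan-2-yl on a carbonyl carbon: the limit of > 10 ug/mL in this assay, at which 3 of the 4 values shown sit.

The compounds shown leave open how far apart compound 2 and compound 4 lie, and whether this exchange alters cytotoxicity at all.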